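This account rests on a few compounds, and the source may have more. Where it says the series, first, only, none or still open, it means among the compounds named here.

Compound 2 `CC1(C)N=C(N)N=C(N)N1c1ccccc1F` gives 4.39 in an assay on isolated protein for inhibition of Dihydrofolate reductase (Mus musculus), at pH 7.20 (a lower number here means a less potent compound, a higher number a more potent compound, by a factor of ten per unit of this negative logarithm), and stands highest of the three measured compounds; compound 1 `CC1(C)N=C(N)N=C(N)N1c1ccccc1N` gives 3.41 and compound 3 `CC1(C)N=C(N)N=C(N)N1c1ccccc1C(F)(F)F` gives 3.03. The measured steps were a number 0.98 log units higher from compound 1 to compound 2 (beyond the scatter), a number 0.38 log units lower from compound 1 to compound 3 (beyond the scatter) and a number 1.36 log units lower from compound 2 to compound 3 (beyond the scatter). Compound 4 `CCc1ccccc1N1C(N)=NC(N)=NC1(C)C` differs from compound 2 by ethyl in place of fluoro on an aromatic carbon. Among the measured compounds shown here, no measured step places ethyl on that carbon; the nearest guide is the trifluoromethyl step from compound 2, where, as here, more heavy atoms enter than leave and the number fell by a large margin. A downward step beyond the scatter is therefore expected, though not necessarily as deep, since compound 1 with amino on the same carbon still gives 3.41. The estimated step is a number 0.79 log units lower from compound 2 to compound 4 (beyond the scatter). Compound 4 is expected at 3.6, within 3 to 4.2.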

Compound 4, logarithm of the reciprocal of the active concentration, log(1/C): 3.38
Compound 4: middle estimate off by 0.22 log units, on the high side; the range from low to high includes it.
By their numbers in this assay, from the lowest: compound 3; then compounds 4 and 1 (each within the scatter of the next); then compound 2.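

Ethyl on this aromatic carbon gives a large fall from fluoro (a number 1.01 log units lower from compound 2 to compound 4 (beyond the scatter)), so a large fall is not confined to trifluoromethyl. Ethyl and trifluoromethyl are still separable (a number 0.35 log units higher from compound 3 to compound 4 (beyond the scatter)), whereas ethyl and amino are not (a number 0.03 log units lower from compound 1 to compound 4 (within the scatter)), which leaves fluoro alone clear of the other three groups. No supporting measurement bears on the reason for this order.

Open, as far as these compounds go, is whether chloro, methoxy or a longer chain such as propyl would stay near fluoro or fall with ethyl. Also open, from the compounds shown here alone, is how plain hydrogen on this carbon compares with all four groups.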